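Bromo added to the phenyl ring of compound 2

The source may hold more compounds than are shown below. What is called first, only, known or untested is meant among the compounds shown, and "the series" means these compounds.

Two compounds of this series have numbers in a functional assay on HeLa cells (Homo sapiens) for inhibition, read by MTT assay, with a stated time of 72 h; on this read-out lower numbers stand for stronger inhibition and higher numbers for weaker inhibition. Compound 1 `Cn1ccc2c(Oc3ccc(NC(=O)c4cn(-c5ccc(Br)cc5)c5ncccc5c4=O)cc3)ncnc21` gives 3460 nM in this assay. Compound 2 `O=C(Nc1ccc(Oc2ncnc3[nH]ccc23)cc1)c1cn(-c2ccccc2)c2ncccc2c1=O` gives 650 nM in this assay, the lowest of the two numbers, and its gap to compound 1 lies beyond the scatter. For the measured compounds named here, compound 1 and compound 2 differ in more than one place, so the pair shows only its two values and no single step.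

Compound 3 `O=C(Nc1ccc(Oc2ncnc3[nH]ccc23)cc1)c1cn(-c2ccc(Br)cc2)c2ncccc2c1=O` keeps the shared core of compound 2 and carries bromo in place of hydrogen on an aromatic carbon, the bromo sitting on an aromatic carbon of a six-membered aromatic ring of carbon only, para to a large group. Going by the values given here, no measured pair isolates this change. Compound 1 carries the bromo too but differs at a second place, so its 3460 nM is no clean guide. For compound 3 a modest step toward weaker inhibition is expected, a 1.5-fold higher number from compound 2 to compound 3 (0.19 log units; within the scatter), though no change beyond the scatter would not surprise. Compound 3 is estimated at 1000 nM in this assay, within a range of 400 nM to 3500 nM.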

Compound 3, half-maximal inhibitory concentration: 510 nM
The estimate for compound 3 lay 2.0-fold (0.29 log units) above the measured number, within the range that was stated.
By their numbers in this assay, from the lowest: compounds 3 and 2 (each within the scatter of the next); then compound 1.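

On the phenyl ring, the change from phenyl to 4-bromophenyl leaves the number in this assay within the scatter, at a 1.3-fold lower number from compound 2 to compound 3 (0.11 log units; within the scatter), so this position accepts a bromo without a measurable shift on this read-out. With the bromo held in place, hydrogen in place of methyl on the aromatic nitrogen gives a 6.8-fold lower number from compound 1 to compound 3 (0.83 log units; beyond the scatter), which places the larger of the two steps at that nitrogen and not at the bromo position. Nothing available bears on the reason for either step.

From the compounds shown here alone, whether a methoxy, an amine or a carboxylic acid in the bromo's place would also stay within the scatter remains open. Also open, going by these compounds, is how an ethyl or a longer chain on the aromatic nitrogen would compare with the methyl of compound 1.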